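The source may report more compounds than this note shows. Statements on the series, on what has been measured and on what is new or still open speak of the compounds shown alone.

Of the compounds shown here, three built on one shared core have been tested, and the core carries a ring whose substituents differ from one compound to the next. Compound 1 `COc1cc(OC)c(OC)cc1/C=C/COC(=O)/C=C/c1ccc(OC)c(OC)c1OC` gives in a functional assay on the whole organism (strain Kunming) with Mus musculus as the target, with a stated time of 0.5 h, at a dose of 300 mg/kg by the intraperitoneal route (a lower number here means a stronger effect, a higher number a weaker effect of the compound at the dose given), a read-out of 25%. Compound 2 `COc1cc(OC)c(OC)cc1/C=C/COC(=O)/C=C/c1c(OC)ccc(OC)c1OC` gives in this assay a read-out of 50%. Compound 3 `COc1cc(OC)c(OC)cc1/C=C/COC(=O)/C=C/c1ccc(F)cc1` gives in this assay a read-out of 0%, the lowest of the three numbers; compound 1 stands a number beyond the scatter higher, and compound 2 is furthest away, also beyond the scatter.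

Compound 4 `COc1cccc(/C=C/C(=O)OC/C=C/c2cc(OC)c(OC)cc2OC)c1` has not yet been measured. It differs from compound 3 in one place: 3-methoxyphenyl in place of 4-fluorophenyl on a double-bonded chain carbon bound to a double-bonded chain carbon. For the measured compounds named here, no pair of measured compounds differing in a single place is at hand, so no step of that kind can guide the expectation. The numbers of compound 1 and compound 2, both carrying methoxy-bearing rings, lie above that of compound 3, and a moderate rise is therefore expected: the estimated step of a number 20 percentage points higher from compound 3 to compound 4 (beyond the scatter) leads to an expected value for compound 4 of 20%, within a range from 0% to 45%.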

Compound 4, a percentage reported as activity, at one dose (the size of the read-out at that dose, not a potency): 50%
Compound 4: the middle estimate sits 30 percentage points below what was measured; measured number above the stated range.
By their numbers in this assay, from the lowest: compound 3; then compound 1; then compounds 2 and 4 (each within the scatter of the next).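

In this assay, the group at this place on the chain clearly matters: 3-methoxyphenyl in place of 4-fluorophenyl gives a number 50 percentage points higher from compound 3 to compound 4 (beyond the scatter). A lower number marks a stronger effect, so at this dose the 4-fluorophenyl group is the better of these two, and this is the first comparison shown in which only one place changes. Nothing measured here explains why the two groups differ.

The compounds shown leave open whether the step follows from losing the fluorine, from gaining the methoxy, or from where each group sits on its ring, and a plain phenyl at this place would give a first reference point. As far as these compounds go, how an amine or a carboxylic acid on this ring would read in this assay also remains open.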